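Swapping Fluoro for Chloro on a Fused Ring

A few compounds are considered here, and "the series" means these few. Any claim that something is new, unique, unknown or untested is made for them only; others in the source may bear on it.

Measured compounds:
compound 1 `CCn1c(=O)/c(=C2\Sc3cccc(F)c3N2C)s/c1=C\c1ccccn1`, 12%
compound 2 `CCn1c(=O)/c(=C2\Sc3c(F)cccc3N2C)s/c1=C\c1ccccn1`, 12%

In an ADME assay on microsomes from liver (Mus musculus) for metabolic stability, with a stated time of 30 min (on this read-out lower numbers stand for a less stable compound and higher numbers for a more stable compound), compound 1 stands level with compound 2, which gives 12%; the two lie within the usual scatter of each other, so neither can be called more stable. Compound 3 `CCn1c(=O)/c(=C2\Sc3cccc(Cl)c3N2C)s/c1=C\c1ccccn1` differs from compound 1 by chloro in place of fluoro on an aromatic carbon. Going by the values given here, no step between two measured compounds shows what such a change does, so the expectation rests on compound 1 alone. The change is expected to amount to no change at the digits printed from compound 1 to compound 3 (within the scatter), not beyond the scatter in either direction. Compound 3 is expected to give 12%, between 4% and 25%.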

Compound 3, percent of the compound remaining: 38%
The estimate for compound 3 lay 26 percentage points below the measured number, and the stated range ends below it.
By their numbers in this assay, from the lowest: compounds 1 and 2 (each within the scatter of the next); then compound 3.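

In this assay, chloro in place of fluoro on this aromatic carbon gives a number 26 percentage points higher from compound 1 to compound 3 (beyond the scatter), a step beyond the scatter. The fluoro compounds, compound 1 and compound 2, could not show that the choice of halogen matters at this position, but this step shows that it does. Nothing measured here accounts for the step.

As far as these compounds go, it remains open whether chloro would give a similar step at the carbon that carries fluoro in compound 2. The effect of a bromo, methyl or methoxy group at the position changed here is also unknown.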